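The source may hold more compounds than are shown below. What is called first, only, known or untested is meant among the compounds shown, and "the series" means these compounds.

In a functional assay on HEK293 cells (Homo sapiens) for cytotoxicity (a lower number here means that less compound is tolerated, a higher number that more compound is tolerated), compound 2 `COc1ccc([C@H]2CC(=O)N(c3cccc([S+](C)[O-])c3)C2)cc1OC1CCCC1` stands at > 10000 nM, which is a limit of the assay and not a number. Compound 1 `COc1ccc([C@H]2CC(=O)N(c3cccc(C(F)(F)F)c3)C2)cc1OC1CCCC1` gives > 10000 nM, also a limit. Compound 3 `COc1ccc([C@H]2CC(=O)N(c3ccc([S+](C)[O-])cc3)C2)cc1OC1CCCC1` gives an actual number, 7510 nM.

Compound 4 `CCCCNc1cccc(N2C[C@@H](c3ccc(OC)c(OC4CCCC4)c3)CC2=O)c1` changes compound 2 at one place: a group of 5 heavy atoms (4 carbon, 1 nitrogen; no ring) in place of a group of 3 heavy atoms (1 carbon, 1 oxygen, 1 sulfur; no ring), on an aromatic carbon. The butylamino group sits on an aromatic carbon, meta to a large group.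

For the measured compounds named here, two measured steps bear on this change. One is a step that the two limits leave unreadable from compound 1 to compound 2. The other is an at least 1.3-fold lower number from compound 2 to compound 3 (0.12 log units; that floor lies within the scatter). Neither shows a large change, so no shift beyond the scatter is expected, though this is weak evidence.

The expected step is an at least 1.1-fold lower number from compound 2 to compound 4 (0.04 log units; that floor lies within the scatter). For compound 4 the estimated value is 9000 nM, with an expected range from 3500 nM to 20000 nM.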

Compound 4, half-maximal cytotoxic concentration: > 10000 nM
Compound 4: only a limit was reported; the forecaster's own chance of this, stated with the estimate: 55%; middle value at least 1.1-fold (0.04 log units) from the limit.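

Compound 4 gives a limit and not a number, as do compound 1 and compound 2, so no step among these three can be read. How far they truly differ in this assay stays open, because all three sit at the same limit: the limit of > 10000 nM in this assay, at which 3 of the 4 values shown sit.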